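Swapping methoxy for dimethylamino on the shared core

A few compounds are considered here, and "the series" means these few. Any claim that something is new, unique, unknown or untested is made for them only; others in the source may bear on it.

Measured so far:
compound 1 `COc1ccc(C2CC(c3ccccc3)=NN2C2=NC(=O)/C(=C3\C(=O)Nc4ccc(Br)cc43)S2)cc1`: 4230 nM
compound 2 `COc1ccc(C2=NN(C3=NC(=O)/C(=C4\C(=O)Nc5ccc(Br)cc54)S3)C(c3ccc(OC)cc3)C2)cc1`: 62700 nM
compound 3 `COc1ccc(C2CC(c3ccc4ccccc4c3)=NN2C2=NC(=O)/C(=C3\C(=O)Nc4ccc(Br)cc43)S2)cc1`: 3370 nM

In a functional assay on cells (Leukemia cell, Homo sapiens) for cytotoxicity, read by sulforhodamine B assay, with a stated time of 48 h (on this read-out higher numbers stand for weaker inhibition of growth and lower numbers for stronger inhibition of growth), compound 1 gives 4230 nM, which is the second highest of the three numbers. Compound 3 sits nearest, with a 1.3-fold lower number from compound 1 to compound 3 (0.10 log units; within the scatter). Compound 2 sits furthest, with a 15-fold higher number from compound 1 to compound 2 (1.17 log units; beyond the scatter); the step of a 19-fold lower number from compound 2 to compound 3 (1.27 log units; beyond the scatter) shows how much a change on the carbon with a double bond to nitrogen can move the number.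

Compound 4 `CN(C)c1ccc(C2CC(c3ccccc3)=NN2C2=NC(=O)/C(=C3\C(=O)Nc4ccc(Br)cc43)S2)cc1` differs from compound 1 in one place: dimethylamino in place of methoxy on an aromatic carbon. This change sits on the aryl ring attached to the saturated carbon of the core, a different place from where compounds 2 and 3 vary. Among the compounds with values here, none of the measured steps therefore touches the same position, and the measured steps give no direct guide to the size or direction of the step in this assay. Both groups carry one hydrogen-bond acceptor and no donor, and the change is small in atom count. The expectation is a step that stays within the usual scatter, estimated as a 1.2-fold lower number from compound 1 to compound 4 (0.08 log units; within the scatter). Compound 4 is thus expected to give about 3500 nM, with a range from 1400 nM to 9000 nM.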

Compound 4, concentration for total growth inhibition: 1290 nM
For compound 4 the middle estimate is 2.7-fold (0.43 log units) above the measured one; the measured number lies below the stated range.
By their numbers in this assay, from the lowest: compound 4; then compounds 3 and 1 (each within the scatter of the next); then compound 2.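

In this assay, the change from 4-methoxyphenyl to 4-(dimethylamino)phenyl gives a 3.3-fold lower number from compound 1 to compound 4 (0.52 log units; beyond the scatter), so the aromatic carbon para to a large group is a place where a single swap moves the number beyond the scatter, though only modestly. Within the data shown here, this is the first view of that place, since the earlier steps all involved other parts of the shared core, and it shows that growth inhibition here can respond to a change on this ring as well as to one on the carbon with a double bond to nitrogen. The step appears even though the two groups have the same counts of hydrogen-bond donors and acceptors, and nothing available here accounts for it.

A single pair cannot show whether dimethylamino itself matters or whether other groups in the same place, such as a primary amine, a hydroxyl, a plain hydrogen or a pyrrolidine ring, would move the number as far or further. As far as these compounds go, it also remains open whether dimethylamino on this ring would give a similar step when combined with the naphthalen-2-yl group of compound 3.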